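Swapping the para substituent on a small lactone core

The source may hold more compounds than are shown below. What is called first, only, known or untested is meant among the compounds shown, and "the series" means these compounds.

Two compounds share one core and differ only in the group on the aromatic ring. Compound 1 `CCOC(=O)C12C(=O)OCC=C1COC2c1ccc(Br)cc1` carries a bromo group, and in a functional assay on HeLa cells (Homo sapiens) for cytotoxicity, read by MTT assay (a higher number here means a weaker inhibitor, a lower number a stronger inhibitor), compound 1 gives 48700 nM. Compound 2 `CCOC(=O)C12C(=O)OCC=C1COC2c1ccc(OC)cc1` carries a methoxy group instead, and in this assay compound 2 gives 18300 nM. For the measured compounds named here, that single exchange, a 2.7-fold lower number from compound 1 to compound 2 (0.43 log units; beyond the scatter), is the only step measured so far, and it leaves compound 2 with the lower of the two numbers. Compound 3 `CCOC(=O)C12C(=O)OCC=C1COC2c1ccc([N+](=O)[O-])cc1` is not yet measured; it changes the ring again, (nitro in place of methoxy on an aromatic carbon). Going by the values given here, nothing measured yet shows what a nitro group does on this core, and the one known step only says that the ring substituent can move the number modestly. The expectation for compound 3 is therefore a step of about a 1.6-fold higher number from compound 2 to compound 3 (0.21 log units; within the scatter), with much room either way, giving an estimated 30000 nM in this assay, within roughly 8000 nM to 90000 nM.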

Compound 3, half-maximal inhibitory concentration: 53400 nM
Estimate against measurement, compound 3: 1.8-fold (0.25 log units) below, within the range that was stated.
By their numbers in this assay, from the lowest: compound 2; then compounds 1 and 3 (each within the scatter of the next).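

In this assay, methoxy now stands apart from both other groups at this position: nitro in its place gives a 2.9-fold higher number from compound 2 to compound 3 (0.47 log units; beyond the scatter), so the lower number of compound 2 was not simply a result of removing bromo. Nitro and bromo, by contrast, cannot be told apart here, with a 1.1-fold higher number from compound 1 to compound 3 (0.04 log units; within the scatter), so two quite different groups give matching results on this core. No measurement here explains why methoxy differs from the other two.

Three groups are too few to show what sets methoxy apart. An amine, a hydroxyl group or a longer chain such as ethoxy at the same position could show whether the lower number is special to methoxy or shared more widely.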